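Aryl halide swap on the side chain of compound 2

This account rests on a few compounds, and the source may have more. Where it says the series, first, only, none or still open, it means among the compounds named here.

Compound 1 `OCC(O)Cn1nc2c(Br)c(Br)c(Br)c(Br)c2n1` — 145%
Compound 2 `OC(CCn1nc2c(Br)c(Br)c(Br)c(Br)c2n1)c1ccc(Br)cc1` — 82%
Compound 3 `C[C@@H](O)CCn1nc2c(Br)c(Br)c(Br)c(Br)c2n1` — 109%

In a functional assay on MCF7 cells (Homo sapiens) for antiproliferative activity, read by MTT assay, with a stated time of 24 h, tested at 12.5 uM (on this read-out lower numbers stand for a stronger effect and higher numbers for a weaker effect at the one concentration tested), compound 2 gives 82%, the lowest of the three numbers; compound 3 stands higher and compound 1 higher still, both beyond the scatter. For the measured compounds named here, the only measured step between compounds differing in one place, a number 36 percentage points lower from compound 1 to compound 3 (beyond the scatter), concerns the hydroxy-bearing chain and not the aryl group. Compound 4 `OC(CCn1nc2c(Br)c(Br)c(Br)c(Br)c2n1)c1cccc(Cl)c1` differs from compound 2 by 3-chlorophenyl in place of 4-bromophenyl on a saturated chain carbon bound to an oxygen on a saturated carbon and a saturated chain carbon. Going by the values given here, no measured step touches that part of the molecule, so the data give no ground to expect a change beyond the scatter. Compound 4 is therefore estimated at 85% (range 65% to 105%), an expected step of a number 3 percentage points higher from compound 2 to compound 4 (within the scatter).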

Compound 4, a percentage reported as activity, at one concentration (the size of the read-out at that concentration, not a potency): 97%
Compound 4: the middle estimate sits 12 percentage points below what was measured; the range from low to high includes it.
By their numbers in this assay, from the lowest: compound 2; then compound 4; then compound 3; then compound 1.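

The aryl group on this saturated chain carbon proves able to move the read-out: in this assay, 3-chlorophenyl in place of 4-bromophenyl gives a number 15 percentage points higher from compound 2 to compound 4 (beyond the scatter) and so weakens the effect. The halogen and the number of its ring place change together in this step, so neither can be held responsible alone. Nothing measured here accounts for the step. The compounds shown leave open how 4-chlorophenyl or 3-bromophenyl would stand at this carbon, which would separate those two changes. They also leave open what an amine or a carboxylic acid on the ring would do.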